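Trimming an isopropyl to a methyl on a shared core

The compounds below may be only part of what the source reports. "The series", "measured", "known", "first", "only" and "open" are said of these compounds alone.

Measured compounds:
- compound 1, `COc1cccc(CNCc2c(C(=O)O)n(Cc3ccc(O)cc3)c3cc(C(C)C)ccc23)c1`: 5340 nM
- compound 2, `COc1ccc(Cn2c(C(=O)O)c(CNCc3cccc(O)c3)c3ccc(C(C)C)cc32)cc1`: 6600 nM

Both compounds were tested in a functional assay on Hep 3B2 cells (Homo sapiens) for antiproliferative activity, read by MTT assay, with a stated time of 72 h; on this read-out lower numbers stand for stronger inhibition and higher numbers for weaker inhibition. Compound 1 gives 5340 nM there, and compound 2 gives 6600 nM. These two numbers lie within the usual scatter of each other, so compound 2 stands alongside compound 1 rather than apart from it; neither can be called the stronger inhibitor of the two. Among the measured compounds shown here, no pair of measured compounds differs in only one place, so no single-change step has been measured yet.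

Compound 3, `COc1ccc(Cn2c(C(=O)O)c(CNCc3cccc(O)c3)c3ccc(C)cc32)cc1`, has not been measured. It differs from compound 2 in one place: methyl in place of isopropyl on an aromatic carbon. The change is small in size, a methyl in place of an isopropyl on an aromatic carbon, and the two compounds share everything else. For the measured compounds named here, with no measured step of this kind to lean on, a modest step toward a higher number in this assay is expected, not far beyond the scatter. Compound 3 is therefore estimated at 9000 nM, with a range from 4000 nM to 25000 nM, which means an expected step of a 1.4-fold higher number from compound 2 to compound 3 (0.13 log units; within the scatter).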

Compound 3, half-maximal inhibitory concentration: 11800 nM
The estimate for compound 3 lay 1.3-fold (0.12 log units) below the measured number; low and high end bracket the measured number.
By their numbers in this assay, from the lowest: compounds 1, 2 and 3 (each within the scatter of the next, the first and the last beyond it).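

Among the compounds shown here, this is the first single-change step in this assay: trimming isopropyl to methyl on an aromatic carbon of the shared core, at a place meta to a fused ring and para to a fused ring, gives a 1.8-fold higher number from compound 2 to compound 3 (0.25 log units; within the scatter). The step stays within the usual scatter of repeated measurements, so this pair does not separate the two groups, and compound 3, with the smaller methyl, cannot be ranked against compound 2, with isopropyl; at this position, the assay has not yet shown that the size of this small carbon group matters. No measured property of either group is available to help interpret the result.

Still open, from the compounds shown here alone, is whether a longer chain, or a group of another kind such as an amine or a carboxylic acid, on this same aromatic carbon would move the number beyond the scatter. Going by these compounds, it is also open whether the same trim from isopropyl to methyl would give a similar result on the core of compound 1, whose other substituents are arranged differently.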